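Benzyl in Place of Methoxyethyl on the Piperidine Amide

A few compounds are considered here, and "the series" means these few. Any claim that something is new, unique, unknown or untested is made for them only; others in the source may bear on it.

Compound 2 `COCCNC(=O)C1CCN(c2nc(N)c3cc(OC)c(OC)cc3n2)CC1` gives 1.13 nM in an assay on isolated protein for displacement of a labelled ligand from Adrenergic receptor alpha-1 (Rattus norvegicus) (on this read-out higher numbers stand for weaker inhibition and lower numbers for stronger inhibition), and compound 1 `CCNC(=O)C1CCN(c2nc(N)c3cc(OC)c(OC)cc3n2)CC1`, with 1.64 nM, stands within the scatter of it. Compound 3 `COc1cc2nc(N3CCC(C(=O)NCc4ccccc4)CC3)nc(N)c2cc1OC` differs from compound 2 by phenyl in place of methoxymethyl on a saturated chain carbon bound to an amide-type nitrogen. For the measured compounds named here, the only step in hand, a 1.5-fold lower number from compound 1 to compound 2 (0.16 log units; within the scatter), changes the same chain at the amide-type nitrogen and stays within the scatter; no step with an aromatic ring there is known. The author therefore expects no change beyond the scatter, a 1.3-fold higher number from compound 2 to compound 3 (0.12 log units; within the scatter), and estimates compound 3 at 1.5 nM, between 0.5 nM and 5 nM in this assay.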

Compound 3, inhibition constant: 0.22 nM
Beside the measured number, compound 3's estimate is 6.8-fold (0.83 log units) above it, and the stated range ends above it.
By their numbers in this assay, from the lowest: compound 3; then compounds 2 and 1 (each within the scatter of the next).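

In this assay the chain on the amide-type nitrogen proves able to shift the read-out: phenyl in place of methoxymethyl gives a 5.1-fold lower number from compound 2 to compound 3 (0.71 log units; beyond the scatter) and phenyl in place of methyl gives a 7.5-fold lower number from compound 1 to compound 3 (0.87 log units; beyond the scatter). For the compounds shown here, the one earlier step, between saturated chains, stayed within the scatter, so these are the first steps beyond it, and both bring in the six-membered aromatic ring. Nothing at hand explains the change. Going by these compounds, whether a longer phenethyl chain or a pyridylmethyl group at this place would read like benzyl stays open.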